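A few compounds are considered here, and "the series" means these few. Any claim that something is new, unique, unknown or untested is made for them only; others in the source may bear on it.

Of the compounds shown here, three built on one shared core have been measured in a functional assay on CHO cells for agonist activity at Alpha-1A adrenergic receptor (Homo sapiens), read by FLIPR and calcium flux; on this read-out lower numbers stand for smaller maximal responses and higher numbers for larger maximal responses. Compound 1 `FC(F)Oc1ccccc1C1Cc2nccn2C1` gives 75%, compound 2 `Clc1ccccc1C1Cc2nccn2C1` gives 56%, and compound 3 `COc1ccccc1C1Cc2nccn2C1` gives 82%. Compound 3 holds the highest of the three numbers; its gap to compound 1 lies within the scatter, while the step of a number 26 percentage points higher from compound 2 to compound 3 (beyond the scatter) is beyond it, as is a number 19 percentage points lower from compound 1 to compound 2 (beyond the scatter). Compound 4 `NC(=O)c1ccccc1C1Cc2nccn2C1` has not yet been measured; it differs from compound 3 in this way: carbamoyl in place of methoxy on an aromatic carbon. Among the measured compounds shown here, no measured step introduces a carbamoyl, so the only guide is that exchanging the group on this aromatic carbon has shifted the maximal response modestly, as in a number 26 percentage points higher from compound 2 to compound 3 (beyond the scatter). Compound 4 is therefore expected to give 65%, between 40% and 90%, which amounts to an estimated step of a number 17 percentage points lower from compound 3 to compound 4 (beyond the scatter).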

Compound 4, largest response reached (Emax), in percent of the reference or control that the assay uses: 87%
Estimate against measurement, compound 4: 22 percentage points below, and the stated range covers the measured number.
By their numbers in this assay, from the lowest: compound 2; then compounds 1, 3 and 4 (each within the scatter of the next, the first and the last beyond it).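

At this aromatic carbon in this assay, carbamoyl, which brings a hydrogen-bond donor, keeps the response level with methoxy, with a number 5 percentage points higher from compound 3 to compound 4 (within the scatter) as the step. It does separate from the other groups: a number 31 percentage points higher from compound 2 to compound 4 (beyond the scatter) is a large step and a number 12 percentage points higher from compound 1 to compound 4 (beyond the scatter) is a modest one, whereas compound 3 stays within the scatter of compound 1. No measurement given here accounts for this. As far as these compounds go, whether an amine or a carboxylic acid on this carbon would hold the response stays open, as does a longer chain on the carbamoyl nitrogen.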